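A few compounds are considered here, and "the series" means these few. Any claim that something is new, unique, unknown or untested is made for them only; others in the source may bear on it.

Measured compounds and values:
Compound 1, `N#Cc1c(Nc2ccc([N+](=O)[O-])cc2)sc2ccccc12`, 37%
Compound 2, `N#Cc1c(Nc2ccc(Cl)cc2)sc2ccccc12`, 45%
Compound 3, `COc1cc2sc(Nc3cccc(O)c3)c(C#N)c2cc1OC`, 67%

All three were run in a functional assay on HUVEC cells (Homo sapiens), read by fluorescence and microscopy, with a stated time of 6 h, tested at 250 nM; on this read-out higher numbers stand for a weaker effect at the one concentration tested and lower numbers for a stronger effect. Compound 1 gives the lowest number of the three. Among the compounds with values here, its nearest neighbour is compound 2, and that pair lies within the scatter; its furthest is compound 3, whose number sits beyond the scatter above it, though compound 3 also carries two extra methoxy groups on the shared core, so no single step links it to compound 1.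

The unmeasured compound 4, `N#Cc1c(Nc2ccc(O)cc2)sc2ccccc12`, keeps the core of compound 1 and changes one group: hydroxy in place of nitro on an aromatic carbon.

Within the data shown here, only one measured step bears on this change: a number 8 percentage points higher from compound 1 to compound 2 (within the scatter). That swap, also at the same place on the same ring, moved the number within the scatter. Compound 3 shows that a hydroxy-bearing ring can go with a higher number, but its other differences leave that uncertain. On balance a small rise is expected, a number 15 percentage points higher from compound 1 to compound 4 (beyond the scatter), possibly still within the scatter.

Compound 4 is therefore estimated at 52%, in the range 35% to 72%.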

Compound 4, a percentage reported as activity, at one concentration (the size of the read-out at that concentration, not a potency): 2%
The estimate for compound 4 lay 50 percentage points above the measured number; measured number below the stated range.
By their numbers in this assay, from the lowest: compound 4; then compounds 1 and 2 (each within the scatter of the next); then compound 3.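

In this assay the group at this place on the ring proves able to change the number a great deal: hydroxy in place of nitro gives a number 35 percentage points lower from compound 1 to compound 4 (beyond the scatter) and hydroxy in place of chloro gives a number 43 percentage points lower from compound 2 to compound 4 (beyond the scatter) on the same core. The swap of chloro for nitro (a number 8 percentage points higher from compound 1 to compound 2 (within the scatter)) had suggested that changes here might matter little, but the two steps to hydroxy are large and lie beyond the scatter, and both go towards a stronger effect at the one concentration tested. Nothing available explains why hydroxy stands apart from nitro and chloro here.

The compounds shown leave open whether this large step belongs to hydroxy alone or would also appear with an amine, a methoxy group or a carboxylic acid at the same place on the shared core. From the compounds shown here alone, compound 3 also carries a hydroxy group, but it differs from compound 4 in more than one place, so it remains open whether hydroxy would give a similarly low number on a core bearing two methoxy groups.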